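Aryl variation on the shared core: compound 4

This account rests on a few compounds, and the source may have more. Where it says the series, first, only, none or still open, it means among the compounds named here.

Compound 2 `CC(=O)Nc1cccc(C2CCN(CCCn3c(-c4ccccc4C(F)(F)F)nc4ccccc43)CC2)c1` stands second highest of the three numbers in an assay for displacement of a labelled ligand from melanin-concentrating hormone receptor 1 (Homo sapiens), read by fluorescence; on this read-out higher numbers stand for weaker inhibition and lower numbers for stronger inhibition: compound 2 gives 50 nM, the nearest is compound 3 `CC(=O)Nc1cccc(C2CCN(CCCn3c(-c4ccc(F)cc4)nc4ccccc43)CC2)c1` with 56 nM, the furthest is compound 1 `CC(=O)Nc1cccc(C2CCN(CCCn3c(-c4ccccc4)nc4ccccc43)CC2)c1` with 2 nM. Compound 4 `CCc1ccc(-c2nc3ccccc3n2CCCN2CCC(c3cccc(NC(C)=O)c3)CC2)cc1` is not yet measured; its change from compound 2 is 4-ethylphenyl in place of 2-(trifluoromethyl)phenyl on an aromatic carbon. Among the measured compounds shown here, the steps that bear on this are a 25-fold higher number from compound 1 to compound 2 (1.40 log units; beyond the scatter) and a 28-fold higher number from compound 1 to compound 3 (1.45 log units; beyond the scatter), both large and toward weaker inhibition, and a 1.1-fold higher number from compound 2 to compound 3 (0.05 log units; within the scatter), which stays within the scatter. Either group placed on the phenyl carried by the shared core, trifluoromethyl or fluoro, has given a number near that of compound 2, while the ethyl of 4-ethylphenyl has no measured counterpart in this series. The step of a 1.2-fold higher number from compound 2 to compound 4 (0.08 log units; within the scatter) is therefore expected to stay within the scatter. Compound 4 is estimated at 60 nM in this assay, with a range from 15 nM to 250 nM.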

Compound 4, half-maximal inhibitory concentration: 32 nM
Beside the measured number, compound 4's estimate is 1.9-fold (0.27 log units) above it, and the stated range covers the measured number.
By their numbers in this assay, from the lowest: compound 1; then compounds 4, 2 and 3 (each within the scatter of the next).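

In this assay, 4-ethylphenyl joins 2-(trifluoromethyl)phenyl and 4-fluorophenyl in lying well away from the unsubstituted phenyl of compound 1, with a 16-fold higher number from compound 1 to compound 4 (1.20 log units; beyond the scatter) as a large step toward weaker inhibition. An all-carbon group therefore gives the same direction of step as the two fluorine-bearing groups, and none of the three substituted compounds goes against it. With a 1.6-fold lower number from compound 2 to compound 4 (0.19 log units; within the scatter) and a 1.8-fold lower number from compound 3 to compound 4 (0.24 log units; within the scatter) both inside the scatter, the three cannot be ranked against one another, and no measurement here accounts for this shift from compound 1.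

Group and place are not separated, since 2-(trifluoromethyl)phenyl alone carries its group at that ring position. Going by these compounds, whether a methoxy group, an amine or a carboxylic acid on this phenyl would follow the same pattern stays open.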